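The source may hold more compounds than are shown below. What is called first, only, known or untested is meant among the compounds shown, and "the series" means these compounds.

Working notes on the series. Three compounds carry the shared core with a changing group on one aromatic carbon: compound 1 `CC1(C)Oc2ccc(C(=O)c3ccccc3)cc2[C@@H](/N=C(\NC#N)Nc2ccc(Cl)cc2)[C@@H]1O`, compound 2 `C=C(c1ccccc1)c1ccc2c(c1)[C@@H](/N=C(\NC#N)Nc1ccc(Cl)cc1)[C@H](O)C(C)(C)O2` and compound 3 `CC(C)(C)C(=O)c1ccc2c(c1)[C@@H](/N=C(\NC#N)Nc1ccc(Cl)cc1)[C@H](O)C(C)(C)O2`. In a functional assay (aorta) with Rattus norvegicus as the target (on this read-out lower numbers stand for stronger inhibition and higher numbers for weaker inhibition), compound 1 gives 7100 nM, compound 2 gives 10700 nM and compound 3 gives 5400 nM. Compound 3 sits at the low end of the three numbers, yet a 1.3-fold lower number from compound 1 to compound 3 (0.12 log units; within the scatter) and a 2.0-fold lower number from compound 2 to compound 3 (0.30 log units; within the scatter), so the three are not separated in this assay; likewise a 1.5-fold higher number from compound 1 to compound 2 (0.18 log units; within the scatter).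

Compound 4 `CC1(C)Oc2ccc(C(=O)Nc3ccccc3)cc2[C@@H](/N=C(\NC#N)Nc2ccc(Cl)cc2)[C@@H]1O` is not yet measured. The change from compound 3 is anilino in place of tert-butyl on a carbonyl carbon. Going by the values given here, no measured pair covers this exchange. Among the compounds with values here, the steps that bear on it are the other exchanges at the same aromatic carbon, a 1.3-fold lower number from compound 1 to compound 3 (0.12 log units; within the scatter) and a 2.0-fold lower number from compound 2 to compound 3 (0.30 log units; within the scatter), both within the scatter, which gives no direction to expect. The estimate for compound 4 in this assay is therefore a step of a 1.1-fold higher number from compound 3 to compound 4 (0.05 log units; within the scatter), a number expected near that of compound 3. Compound 4 is expected to give 6000 nM, in a range from 2500 nM to 15000 nM.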

Compound 4, half-maximal inhibitory concentration: > 100000 nM
Compound 4 was reported as a limit (the forecaster's own chance of this, stated with the estimate: 5%); at least 16-fold (1.22 log units) between middle value and limit.
By their numbers in this assay, from the lowest: compounds 3, 1 and 2 (each within the scatter of the next). At a limit, above all of these: compound 4.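

Compound 4 is reported only as a limit in this assay: the limit of > 100000 nM in this assay, at which 1 of the 4 values shown sits. Going by these compounds alone, the earlier exchanges on this aromatic carbon all stayed within the scatter, whereas phenylcarbamoyl is the first group here to go beyond it (an at least 18-fold higher number from compound 3 to compound 4 (1.26 log units; beyond the scatter); an at least 14-fold higher number from compound 1 to compound 4 (1.14 log units; beyond the scatter); an at least 9.3-fold higher number from compound 2 to compound 4 (0.97 log units; beyond the scatter)). The position therefore does not accept every group carried on a carbonyl carbon alike: benzoyl and (tert-butyl)carbonyl are not separated, while anilino on that same carbonyl carbon stands clearly apart from both.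

The compounds shown do not tell whether the amide hydrogen or the anilino group as a whole accounts for the step, which a methylanilino or a benzylamino group on the same carbonyl carbon would address. As far as these compounds go, how a carboxylic acid or a small alkylamino group on that carbonyl carbon would read also stays open.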